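A smaller side group on compound 3

The source may report more compounds than this note shows. Statements on the series, on what has been measured and on what is new or still open speak of the compounds shown alone.

Of the compounds shown here, three have been measured so far in a functional assay on HepG2 cells (Homo sapiens) for inhibition, read by MTT assay, with a stated time of 48 h; a lower number here means a stronger inhibitor, a higher number a weaker inhibitor. Compound 2 (`Cc1nc(N(C)c2ccc([Se]C#N)c(C)c2)c2ccccc2n1`) gives 9 nM in this test, compound 3 (`COc1ccc(N(C)c2nc(C)nc3ccccc23)cc1C(=O)NCC[Se]C#N`) gives 179 nM and compound 1 (`COc1ccc(N(C)c2nc(C)nc3ccccc23)cc1OCCCCCC[Se]C#N`) gives 4890 nM at the top of the set. Compound 3 therefore sits in the middle, well apart from both neighbours.

Compound 4 (`COc1ccc(N(C)c2nc(C)nc3ccccc23)cc1OCC[Se]C#N`) has not yet been measured. Compared with compound 3, it carries a group of 6 heavy atoms (3 carbon, 1 nitrogen, 1 oxygen, 1 selenium; no ring) in place of a group of 8 heavy atoms (4 carbon, 2 nitrogen, 1 oxygen, 1 selenium; no ring), on an aromatic carbon and this site is ortho to a methoxy group.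

Within the data shown here, only one measured step involves this site, and it is large and beyond the scatter (a 27-fold lower number from compound 1 to compound 3 (1.44 log units; beyond the scatter)). In that step the group became smaller and also changed in make-up, so the two changes cannot be told apart. Making the group smaller again might lower the number further, yet compound 4 also loses the amide present in compound 3, the compound with the lower number in that step. With these two considerations pulling in opposite directions, a modest rise in this assay is expected, with real uncertainty about its direction. The expected step is modest (a 2.0-fold higher number from compound 3 to compound 4 (0.29 log units; within the scatter)). For compound 4 the estimated value is 350 nM (expected range 70 nM to 1800 nM).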

Compound 4, half-maximal inhibitory concentration: 14 nM
The estimate for compound 4 lay 25-fold (1.40 log units) above the measured number; measured number below the stated range.
By their numbers in this assay, from the lowest: compounds 2 and 4 (each within the scatter of the next); then compound 3; then compound 1.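

Compound 4 separates two changes that were mixed in the earlier step at this position. With the oxygen link kept and only the chain shortened, this assay shows a 350-fold lower number from compound 1 to compound 4 (2.54 log units; beyond the scatter), so chain length alone can shift the number strongly at this site. The second step, a 13-fold lower number from compound 3 to compound 4 (1.11 log units; beyond the scatter), shows that an amide is not needed for a low number here: the entering group has no amide and no hydrogen-bond donor, yet compound 4 reads lower than compound 3, though this step also changes the size of the group, so make-up and size remain tied together in it. Nothing available explains why either change has this effect.

The oxygen-linked chains shown have only two lengths, so it stays open whether the number climbs steadily with a longer chain or jumps at some intermediate length. It also remains to be seen how a short chain joined through an amine instead of the oxygen, or one carrying sulfur in place of selenium, would read in this assay.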